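Carbamate nitrogen substitution in a biaryl acetic acid series

The source may hold more compounds than are shown below. What is called first, only, known or untested is meant among the compounds shown, and "the series" means these compounds.

For the measured compounds named here, compound 1 `CCN(Cc1cc(C(F)(F)F)ccc1-c1cc(CC(=O)O)ccc1OC)C(=O)OCc1cccc(Cl)c1` and compound 2 `COc1ccc(CC(=O)O)cc1-c1ccc(C(F)(F)F)cc1CN(C(=O)OCc1ccccc1)C1CCCC1` share a core and differ from one another in more than one place, so no single step joins them. In an assay on isolated protein for inhibition of prostaglandin D2 receptor 2 (Homo sapiens), read by flow cytometry, with stated times of 15 min and 5 min (on this read-out higher numbers stand for weaker inhibition and lower numbers for stronger inhibition), compound 1 gives 7 nM, and compound 2 gives 53 nM; compound 2 therefore carries the higher of the two numbers, and its gap to compound 1 lies beyond the scatter. Compound 3 `COc1ccc(CC(=O)O)cc1-c1ccc(C(F)(F)F)cc1CNC(=O)OCc1ccccc1` differs from compound 2 by one change only: hydrogen in place of cyclopentyl on an amide-type nitrogen. Going by the values given here, no pair of measured compounds isolates this change, so its effect is not fixed by the data. The step from compound 2 to compound 3 is expected to be a 4.7-fold higher number from compound 2 to compound 3 (0.67 log units; beyond the scatter), toward weaker inhibition and beyond the scatter. For compound 3 the estimate in this assay is 250 nM, within a range from 60 nM to 1500 nM.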

Compound 3, half-maximal inhibitory concentration: 709 nM
Beside the measured number, compound 3's estimate is 2.8-fold (0.45 log units) below it, and the stated range covers the measured number.
By their numbers in this assay, from the lowest: compound 1; then compound 2; then compound 3.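

In this assay, for the compounds shown here, the step to hydrogen on the amide-type nitrogen is a 13-fold higher number from compound 2 to compound 3 (1.13 log units; beyond the scatter), the first single-change reading at this position. For this pair, cyclopentyl on the nitrogen goes with stronger inhibition than hydrogen, so the nitrogen substituent has a large effect on the number here, though one pair fixes no trend. Nothing at hand bears on the reason for the size of this step.

Still open, as far as these compounds go, is how the number moves with other groups on this nitrogen, such as methyl, isopropyl or cyclohexyl in place of cyclopentyl. Compound 1 differs from compound 2 in more than one place, so the contribution of its ethyl group on this nitrogen cannot be separated from that of its other difference.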